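The source may hold more compounds than are shown below. What is called first, only, known or untested is meant among the compounds shown, and "the series" means these compounds.

In a functional assay on HT-29 cells (Homo sapiens) for inhibition, read by luminescence and CellTiter-Glo, with a stated time of 24 h (on this read-out lower numbers stand for an effect already at smaller amounts and higher numbers for an effect only at larger amounts of compound), compound 1 (`CCCn1nc(C(=O)N[C@H]2COc3ccccc3N(C)C2=S)nc1Cc1ccccc1`) gives 288 nM while compound 2 (`CCCCn1nc(C(=O)N[C@H]2COc3ccccc3N(C)C2=S)nc1Cc1ccccc1`) gives 510 nM and compound 3 (`CC(C)n1nc(C(=O)N[C@H]2COc3ccccc3N(C)C2=S)nc1Cc1ccccc1`) gives 360 nM on the shared core. Compound 1 does not stand apart from the other two: its steps to both stay within the scatter, as does the remaining step (a 1.4-fold lower number from compound 2 to compound 3 (0.15 log units; within the scatter)).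

Compound 4 (`CC(C)CCn1nc(C(=O)N[C@H]2COc3ccccc3N(C)C2=S)nc1Cc1ccccc1`) is still unmeasured. It differs from compound 1 by isopropyl in place of methyl on a saturated chain carbon, two bonds along the chain from an aromatic nitrogen, the same difference read as propyl to isopentyl.

The closest measured change is methyl in place of hydrogen on a saturated chain carbon (a 1.8-fold higher number from compound 1 to compound 2 (0.25 log units; within the scatter)). The branched comparison is isopropyl in place of propyl (a 1.3-fold higher number from compound 1 to compound 3 (0.10 log units; within the scatter)). Going by the values given here, neither moved the number beyond the scatter, and no measured compound carries an isopentyl chain, so the extrapolation is loose.

A small move towards a higher number is expected, not clearly beyond the scatter, and the estimated step is (a 1.8-fold higher number from compound 1 to compound 4 (0.26 log units; within the scatter)). For compound 4 the estimated value is 520 nM with an expected range from 240 nM to 1200 nM as working limits.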

Compound 4, half-maximal effective concentration: 3640 nM
The estimate for compound 4 lay 7.0-fold (0.85 log units) below the measured number; measured number outside the range, above it.
By their numbers in this assay, from the lowest: compounds 1, 3 and 2 (each within the scatter of the next); then compound 4.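

In this assay, the isopentyl chain on the aromatic nitrogen separates compound 4 from all three earlier compounds, with a 13-fold higher number from compound 1 to compound 4 (1.10 log units; beyond the scatter), a 10-fold higher number from compound 3 to compound 4 (1.00 log units; beyond the scatter) and a 7.1-fold higher number from compound 2 to compound 4 (0.85 log units; beyond the scatter), whereas propyl, butyl and isopropyl had stayed within the scatter of one another. The last of these steps is methyl in place of hydrogen on a saturated chain carbon bound to two saturated chain carbons, and it goes beyond the scatter, while the other methyl in place of hydrogen on this chain, a 1.8-fold higher number from compound 1 to compound 2 (0.25 log units; within the scatter), does not, so across these four compounds the number does not rise evenly as carbon is added at this position. Nothing available on these compounds accounts for this jump.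

A straight pentyl chain on the same nitrogen would show whether the jump follows chain length or the branch at the chain end. Going by these compounds, it also remains open whether a hydroxyl or an amine at the end of the butyl chain of compound 2 would hold the number near that of compound 2 or move it towards that of compound 4.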